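Adding a Butyl Chain to the Core of Compound 1

The source may report more compounds than this note shows. Statements on the series, on what has been measured and on what is new or still open speak of the compounds shown alone.

Compound 1 `CN1CCC[C@H]1COc1cccnc1` gives 100% in an assay on K177 cells with Neuronal acetylcholine receptor; alpha4/beta2 (Homo sapiens) as the target (a lower number here means a smaller maximal response, a higher number a larger maximal response), the highest of the three measured values. Compound 2 `Cc1ncccc1OC[C@@H]1CCCN1C` reaches 26.7%, and compound 3 `CN1CCC[C@H]1COc1cccnc1Br` reaches 12.3%. Compound 4 `CCCCc1cncc(OC[C@@H]2CCCN2C)c1` has not yet been measured; it differs from compound 1 by butyl in place of hydrogen on an aromatic carbon, placed two atoms from the ring nitrogen and meta to a group of 8 heavy atoms. The two measured additions to the core both went in one direction: a number 73.3 percentage points lower from compound 1 to compound 2 (beyond the scatter) and a number 87.7 percentage points lower from compound 1 to compound 3 (beyond the scatter). Compound 4 carries its chain on a different aromatic carbon, so the size may differ, but a drop is expected, a number 60 percentage points lower from compound 1 to compound 4 (beyond the scatter). Compound 4 is therefore estimated at 40%, within 10% to 90%.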

Compound 4, largest response reached (reported as maximum), in percent of the reference or control that the assay uses: 14%
Beside the measured number, compound 4's estimate is 26 percentage points above it, and the stated range covers the measured number.
By their numbers in this assay, from the lowest: compounds 3 and 4 (each within the scatter of the next); then compound 2; then compound 1.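

In this assay, the response falls by a large step, a number 86 percentage points lower from compound 1 to compound 4 (beyond the scatter), when butyl sits on the aromatic carbon two atoms from the ring nitrogen and meta to a group of 8 heavy atoms. The loss seen with methyl and bromo therefore also appears with a carbon chain on a different aromatic carbon, and none of the three substituted compounds goes against this. No measurement here explains the fall.

On these data alone, whether a shorter chain such as ethyl would keep more of the response at this carbon remains open. So does the effect of a hydroxyl group or an amine there.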